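Chloro substitution on the triazole nitrogen substituent

This account rests on a few compounds, and the source may have more. Where it says the series, first, only, none or still open, it means among the compounds named here.

Compound 1 `CN(CCNCc1cn(-c2ccccc2)nn1)CCNc1ccnc2cc(Cl)ccc12`: 26000 nM
Compound 2 `CN(CCNCc1cn(-c2ccc(Cl)cc2)nn1)CCNc1ccnc2cc(Cl)ccc12`: 9500 nM
Compound 3 `CN(CCNCc1cn(Cc2nc3ccccc3[nH]2)nn1)CCNc1ccnc2cc(Cl)ccc12`: 164000 nM

In a functional assay on HCC827 cells (Homo sapiens) for antiproliferative activity, read by sulforhodamine B assay, with a stated time of 72 h (on this read-out higher numbers stand for weaker inhibition and lower numbers for stronger inhibition), compound 1 gives 26000 nM and compound 2 gives 9500 nM; the change between them is chloro in place of hydrogen on an aromatic carbon, and it made a step of a 2.7-fold lower number from compound 1 to compound 2 (0.44 log units; beyond the scatter). Compound 3 gives 164000 nM; it differs from compound 1 by (1H-benzimidazol-2-yl)methyl in place of phenyl on an aromatic nitrogen, with a step of a 6.3-fold higher number from compound 1 to compound 3 (0.80 log units; beyond the scatter), and from compound 2 by a 17-fold higher number from compound 2 to compound 3 (1.24 log units; beyond the scatter).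

Compound 4 `CN(CCNCc1cn(Cc2nc3cc(Cl)ccc3[nH]2)nn1)CCNc1ccnc2cc(Cl)ccc12` is not yet measured. It differs from compound 3 by chloro in place of hydrogen on an aromatic carbon, the same kind of change as from compound 1 to compound 2; the place differs in that the ring is part of a fused or bridged system of two rings, meta to a fused ring and para to a fused ring, rather than para to a large group. A step of a 2.1-fold lower number from compound 3 to compound 4 (0.31 log units; beyond the scatter) is expected for compound 4 in this assay, resting on the earlier step of a 2.7-fold lower number from compound 1 to compound 2 (0.44 log units; beyond the scatter) and set smaller than it. Compound 4 is estimated at 80000 nM, between 30000 nM and 200000 nM.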

Compound 4, half-maximal inhibitory concentration: 65000 nM
Compound 4: the middle estimate sits 1.2-fold (0.09 log units) above what was measured; the measured number falls inside the stated range.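

In this assay, chloro in place of hydrogen carries over from the phenyl compound to the (1H-benzimidazol-2-yl)methyl compound with its size kept, giving a 2.5-fold lower number from compound 3 to compound 4 (0.40 log units; beyond the scatter), and the two steps agree: the same change on two cores in this assay, a 2.7-fold lower number (0.44 log units; beyond the scatter) from compound 1 to compound 2 and a 2.5-fold lower number (0.40 log units; beyond the scatter) from compound 3 to compound 4, 1.1-fold (0.04 log units) apart, within the scatter of two such steps. The gain does not make up for the change of group on the triazole nitrogen, which still leaves a 2.5-fold higher number from compound 1 to compound 4 (0.40 log units; beyond the scatter) and a 6.8-fold higher number from compound 2 to compound 4 (0.84 log units; beyond the scatter). Among these compounds, this rests on only two pairs with chloro in different places, so it shows no general rule and gives no reason for the match.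

Still open, from the compounds shown here alone, is whether fluoro, methyl or methoxy in the same place gives a similar step. Also open, going by these compounds, is whether chloro at other positions of the benzimidazole does so.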